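This account rests on a few compounds, and the source may have more. Where it says the series, first, only, none or still open, it means among the compounds named here.

Going by the values given here, in a functional assay on HepG2 cells (Homo sapiens) for cytotoxicity, read by MTT assay, with a stated time of 72 h (on this read-out lower numbers stand for stronger inhibition and higher numbers for weaker inhibition), compound 2 `CNC(=O)c1cc(Oc2ccc(C(=O)/C=C/c3cccc(Br)c3)cc2)ccn1` gives 2870 nM, the lower of the two numbers so far, while compound 1 `CNC(=O)c1cc(Oc2ccc(/C=C/C(=O)c3ccc(Cl)cc3)cc2)ccn1` gives 36600 nM, a gap beyond the usual scatter. Compound 3 `CNC(=O)c1cc(Oc2ccc(C(=O)/C=C/c3cccc(Cl)c3Cl)cc2)ccn1` has not yet been measured. It differs from compound 2 in one place: 2,3-dichlorophenyl in place of 3-bromophenyl on a double-bonded chain carbon bound to a double-bonded chain carbon. Among the compounds with values here, no measured pair shows a swap of this kind, so the step cannot be read off earlier data; a step within the scatter is expected, in either direction. Compound 3 is estimated at 3200 nM in this assay, with a range from 1100 nM to 9500 nM. The expected step is a 1.1-fold higher number from compound 2 to compound 3 (0.05 log units; within the scatter).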

Compound 3, half-maximal inhibitory concentration: > 50000 nM
Compound 3: no number, only a limit (the forecaster's own chance of this, stated with the estimate: 5%); middle value at least 15-fold (1.19 log units) away from the limit.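

At this place, on a double-bonded chain carbon bound to a double-bonded chain carbon, a swap of one halogenated phenyl for another can move the read-out well beyond the scatter: in this assay, 2,3-dichlorophenyl in place of 3-bromophenyl gives an at least 17-fold higher number from compound 2 to compound 3 (1.24 log units; beyond the scatter). The reading for compound 3 is a limit of the assay, not a number: the limit of > 50000 nM in this assay, at which 1 of the 3 values shown sits.

As far as these compounds go, it remains open whether the step follows the loss of bromine or the entry of two chlorines. From the compounds shown here alone, how a single chlorine or an amine on the phenyl in that place would read is also open.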